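The source may hold more compounds than are shown below. What is called first, only, known or untested is meant among the compounds shown, and "the series" means these compounds.

Working notes on the series. The set rests on two measured compounds. Compound 1 `CCN(CC)S(=O)(=O)c1ccc(S(=O)(=O)N2CCC[C@@H](C(=O)NC3CN(C(=O)OC(C)(C)C)C3)C2)cc1` is the reference point: in a functional assay on MIA PaCa-2 cells (Homo sapiens) for inhibition, read by MTT assay, with a stated time of 3 days (on this read-out lower numbers stand for stronger inhibition and higher numbers for weaker inhibition), compound 1 gives 100 nM, the lowest of the two numbers recorded. Within the data shown here, compound 2 `CCOC(=O)[C@@H]1CCCN(S(=O)(=O)c2ccc(S(=N)(=O)N(CC)CC)cc2)C1` differs from compound 1 in more than one place, so no single step is drawn between them; in this assay compound 2 gives 900 nM, and the gap to compound 1 lies beyond the scatter.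

Compound 3 `CCN1CC(NC(=O)[C@@H]2CCCN(S(=O)(=O)c3ccc(S(=O)(=O)N(CC)CC)cc3)C2)C1` is the next compound to be run. It keeps the core of compound 1 and differs from it in one place: ethyl in place of tert-butoxycarbonyl on an amine nitrogen in a ring. Among the measured compounds shown here, no measured pair shows this kind of exchange, so the direction of the step is an open question. The expectation is a small loss, with a 2.0-fold higher number from compound 1 to compound 3 (0.30 log units; within the scatter) as the estimated step, since the only firm anchor is the value of compound 1 in this assay, 100 nM. Compound 3 is therefore estimated at 200 nM, within a range of 50 nM to 800 nM.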

Compound 3, half-maximal inhibitory concentration: > 10000 nM
Compound 3 was reported as a limit; the forecaster's own chance of this, stated with the estimate: 5%; at least 50-fold (1.69 log units) between middle value and limit.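

In this assay, among these compounds, ethyl in place of tert-butoxycarbonyl on the amine nitrogen in the four-membered ring gives an at least 100-fold higher number from compound 1 to compound 3 (2.00 log units; beyond the scatter), the first evidence that the group on this nitrogen can decide the read-out. For compound 3 the entry > 10000 nM is a limit of the assay and not a number. The step therefore has a lower bound but no measured size: the limit of > 10000 nM in this assay, at which 1 of the 3 values shown sits.

As far as these compounds go, how an acetyl group, a benzyl group, a longer alkyl chain or the free amine on this nitrogen would read remains open, as does whether any of them would retain the value of compound 1, 100 nM. With one exchange at this position, the pair cannot show which part of tert-butoxycarbonyl matters.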